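Sulfonyl aryl swap on the piperazine of compound 2

The compounds below may be only part of what the source reports. "The series", "measured", "known", "first", "only" and "open" are said of these compounds alone.

For the measured compounds named here, compound 2 `COC(=O)c1ccc(C2SCC(=O)N2c2ccc(N3CCN(S(=O)(=O)c4ccc(OC)cc4)CC3)cn2)c(OC)c1` gives 54500 nM in a functional assay on K562 cells (Homo sapiens) for antiproliferative activity, read by MTT assay and trypan blue exclusion, with a stated time of 72 h (a higher number here means a weaker inhibitor, a lower number a stronger inhibitor), the only number. Compound 1 `COC(=O)c1ccc(C2SCC(=O)N2c2ccc(N3CCN(Cc4cccc(C)c4)CC3)cn2)c(OC)c1` reaches only a limit there, > 100000 nM, as the limit of > 100000 nM in this assay, at which 1 of the 2 values shown sits, shows. Going by the values given here, the step of an at least 1.8-fold lower number from compound 1 to compound 2 (0.26 log units; that floor lies within the scatter) is the sole measured step; it concerns the piperazine substituent, not the aryl of the sulfonyl. Compound 3 `COC(=O)c1ccc(C2SCC(=O)N2c2ccc(N3CCN(S(=O)(=O)c4ccc([N+](=O)[O-])cc4)CC3)cn2)c(OC)c1` differs from compound 2 by nitro in place of methoxy on an aromatic carbon. Among the compounds with values here, no measured step bears on this change, so in this assay the step of a 1.2-fold lower number from compound 2 to compound 3 (0.08 log units; within the scatter) is expected to stay within the scatter. Compound 3 is estimated at 45000 nM, between 15000 nM and 150000 nM.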

Compound 3, half-maximal inhibitory concentration: 65200 nM
Estimate against measurement, compound 3: 1.4-fold (0.16 log units) below; the measured number falls inside the stated range.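

In this assay, nitro in place of methoxy on the aromatic carbon para to a large group gives a 1.2-fold higher number from compound 2 to compound 3 (0.08 log units; within the scatter), so the two groups cannot be told apart at this position. Compound 1 remains at a limit of the assay, > 100000 nM, and not a number. The second sulfonyl comparison therefore adds only another floor: an at least 1.5-fold lower number from compound 1 to compound 3 (0.18 log units; that floor lies within the scatter).

On these data alone, what an amine or a carboxylic acid at this position would do stays open. So does the true size of the step away from 3-methylbenzyl.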